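Swapping a methyl for trifluoromethoxy on a pancreatic-cell inhibitor

The source may report more compounds than this note shows. Statements on the series, on what has been measured and on what is new or still open speak of the compounds shown alone.

Compound 1 `Cc1nnsc1CO/N=C/c1c(C)nn(C)c1Oc1ccc(I)cc1`: in a functional assay on PANC-1 cells (Homo sapiens) for inhibition, read by MTT assay, with a stated time of 48 h (on this read-out higher numbers stand for weaker inhibition and lower numbers for stronger inhibition), compound 1 gives > 50000 nM, which is a limit of the assay and not a number.
Compound 2 `Cc1ccc(Oc2c(/C=N/OCc3snnc3C)c(C)nn2C)cc1`: in this assay compound 2 gives > 50000 nM, again a limit of the assay and not a number.

Within the data shown here, the only measured step, a step that the two limits leave unreadable from compound 1 to compound 2, cannot be read because of the limit of > 50000 nM in this assay, at which 2 of the 2 values shown sit. Compound 2 therefore stands at the limit, with nothing to rank it against. Compound 3 `Cc1nnsc1CO/N=C/c1c(C)nn(C)c1Oc1ccc(OC(F)(F)F)cc1` differs from compound 2 by trifluoromethoxy in place of methyl on an aromatic carbon. Among the measured compounds shown here, no measured step covers this change, and the step from compound 1 to compound 2 says nothing about its size or direction. With both measured compounds at the limit, compound 3 is expected to sit at the limit as well. The step that the limit leaves unreadable from compound 2 to compound 3 is estimated as no change beyond the scatter. For compound 3 the estimate in this assay is 60000 nM, within 15000 nM to 250000 nM.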

Compound 3, half-maximal inhibitory concentration: > 50000 nM
Compound 3: a limit, no number; the forecaster's own chance of this, stated with the estimate: 75%; the middle value does not contradict the limit.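

No step among compound 1, compound 2 and compound 3 can be read, because all three share one limit, not a number: the limit of > 50000 nM in this assay, at which 3 of the 3 values shown sit.

The compounds shown leave open how strongly any of the three inhibits, and whether iodo, methyl or trifluoromethoxy on that aromatic carbon makes any difference.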